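The source may report more compounds than this note shows. Statements on the series, on what has been measured and on what is new or still open speak of the compounds shown alone.

Three compounds have numbers so far in a functional assay on SK-BR-3 cells (Homo sapiens) for cytotoxicity, read by sulforhodamine B assay, with a stated time of 72 h (a lower number here means that less compound is needed, a higher number that more compound is needed for the effect), as follows
- compound 1 `Cc1coc2cc(-c3cccc(O)c3)oc(=O)c12` gives 1.61 uM
- compound 2 `Cc1ccc(-c2cc3occ(C)c3c(=O)o2)cc1C` gives 14.6 uM
- compound 3 `COc1cc(OC)cc(-c2cc3occ(C)c3c(=O)o2)c1` gives 0.28 uM

Of these three, compound 3 has the lowest number, so it needs the least compound for the effect. Compound 1 lies nearest to it and compound 2 furthest, and both gaps go beyond the usual scatter of repeated measurements.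

The next compound, compound 4 `COc1cc(-c2cc3occ(C)c3c(=O)o2)cc(OC)c1OC`, differs from compound 3 in one place (methoxy in place of hydrogen on an aromatic carbon), with methoxy in place of hydrogen on an aromatic carbon, ortho to two methoxy groups and para to a large group. Going by the values given here, no pair of measured compounds differs by a single change, so there is no direct precedent for the size of this step, and the expectation is correspondingly loose. Compound 3 (0.28 uM) already carries two methoxy groups, and the entering group is one more of the same kind. The estimated step of a 1.6-fold higher number from compound 3 to compound 4 (0.21 log units; within the scatter) is therefore expected to stay within the scatter in this assay, this assay, leaning slightly towards a higher number. For compound 4 the estimated value is 0.45 uM, with an expected range from 0.1 uM to 2.5 uM as the likely span.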

Compound 4, concentration for half-maximal effect: 0.44 uM
Compound 4: the middle estimate sits 1.0-fold (0.01 log units) above what was measured; the measured number falls inside the stated range.
By their numbers in this assay, from the lowest: compounds 3 and 4 (each within the scatter of the next); then compound 1; then compound 2.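

Going by these compounds alone, this is the first comparison where only one thing differs. In this assay, a methoxy in place of hydrogen on the aromatic carbon, ortho to two methoxy groups and para to a large group, gives a 1.6-fold higher number from compound 3 to compound 4 (0.20 log units; within the scatter), a step that cannot be told apart from the ordinary variation between repeated measurements. So this position accepts one more methoxy group without a detectable effect on the cytotoxicity read-out, and compound 3 and compound 4 stand as equals here. No further data accompany this result that could explain it.

The compounds shown do not reveal how an amine, a carboxylic acid or a longer chain such as propoxy would behave at this same position, so the tolerance seen here is established for methoxy alone. Within the data shown here, they also contain no pair that isolates the contribution of the two methoxy groups already present in compound 3, which leaves open how much those groups matter for the effect.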